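Swapping a Sulfonamide for a Basic Amine

This account rests on a few compounds, and the source may have more. Where it says the series, first, only, none or still open, it means among the compounds named here.

Of the compounds shown here, three have been measured in a functional assay for antagonist activity at melanin-concentrating hormone receptor 1 (Homo sapiens); a lower number here means a stronger inhibitor, a higher number a weaker inhibitor. Compound 1 `N#Cc1cccc([C@]23CCC(N(CCN4CC[C@@H](O)C4)C(=O)Nc4cccc(Cl)c4)CC2C3)c1` gives 27 nM in this assay. Compound 2 `CC(C)N(CCN(C(=O)Nc1cccc(F)c1)C1CC[C@]2(c3cccc(C#N)c3)CC2C1)C(C)C` gives 2.1 nM. Compound 3 `CC(C)N(CCN(C(=O)Nc1ccc(F)c(Cl)c1)C1CC[C@]2(c3cccc(CNS(C)(=O)=O)c3)CC2C1)C(C)C` gives 18 nM. Among these three numbers compound 3 stands second highest: its nearest neighbour is compound 1, whose value lies within the usual scatter of compound 3, so the two cannot be told apart; compound 2 sits furthest away, with a clearly lower number that lies beyond the scatter, and is therefore the stronger inhibitor of the pair.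

Compound 4 `CC(C)N(CCN(C(=O)Nc1ccc(F)c(Cl)c1)C1CC[C@]2(c3cccc(CN(C)C)c3)CC2C1)C(C)C` has not yet been measured. It differs from compound 3 in one place: dimethylamino in place of methanesulfonamido on a saturated chain carbon bound to an aromatic carbon. The rest of the molecule, including the shared core and the substituted aryl urea, is unchanged.

Among the measured compounds shown here, no measured pair in this set shows the same change, so the expectation rests on general experience with this series rather than on a recorded step. The change removes a hydrogen-bond donor and brings in a basic nitrogen at the same spot. Compound 4 is expected to remain an active antagonist, with a step from compound 3 of a 1.8-fold lower number from compound 3 to compound 4 (0.26 log units; within the scatter) that may be a mild gain or none beyond the scatter. The estimate for compound 4 in this assay is 10 nM, within a range from 3 nM to 35 nM.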

Compound 4, inhibition constant: 13 nM
Compound 4: the middle estimate sits 1.3-fold (0.11 log units) below what was measured; low and high end bracket the measured number.
By their numbers in this assay, from the lowest: compound 2; then compounds 4, 3 and 1 (each within the scatter of the next, the first and the last beyond it).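

In this assay, among the compounds shown here, this pair gives the first direct reading at this position: dimethylamino in place of methanesulfonamido, on a saturated chain carbon bound to an aromatic carbon, gives a 1.4-fold lower number from compound 3 to compound 4 (0.14 log units; within the scatter) and so leaves the two compounds indistinguishable. Within this pair, a group of 5 heavy atoms with 1 hydrogen-bond donor and a group of 3 heavy atoms with 0 hydrogen-bond donors therefore support the same level of activity, and the hydrogen-bond donor of the methanesulfonamido group is not required to reach it. Nothing measured here explains why two such different groups give matching results.

The compounds shown leave open how far this tolerance extends, for instance whether a carboxylic acid, a primary amine or a longer chain ending in dimethylamino on the same carbon would also hold the activity of compound 3 and compound 4. As far as these compounds go, it also remains open whether the same swap would give a similar result with the other side chain and the other aryl urea seen in compound 1, since this single pair speaks only for its own surroundings.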